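The source may hold more compounds than are shown below. What is called first, only, known or untested is meant among the compounds shown, and "the series" means these compounds.

In a functional assay on cells (Platelet, Homo sapiens) for inhibition (a lower number here means a stronger inhibitor, a higher number a weaker inhibitor), compound 1 `CCOC(=O)c1ccc(-c2nn(Cc3cccc(OC)c3)c3ccccc23)cc1` gives 260 nM. Compound 2 `CCOC(=O)c1ccc(-c2nn(Cc3ccc(OC)cc3)c3ccccc23)cc1` gives 620 nM in this assay. For the measured compounds named here, the only measured step, a 2.4-fold higher number from compound 1 to compound 2 (0.38 log units; beyond the scatter), is the sole comparison available. Among the two measured numbers compound 2 carries the higher one, so it is the weaker inhibitor of the pair. Compound 3 `CCOC(=O)c1ccc(-c2nn(-c3ccco3)c3ccccc23)cc1` differs from compound 2 by furan-2-yl in place of 4-methoxybenzyl on an aromatic nitrogen. The measured step of a 2.4-fold higher number from compound 1 to compound 2 (0.38 log units; beyond the scatter) concerns only where the methoxy group sits on the benzyl group, and that whole group now leaves, so it says little about placing a five-membered ring with one hetero atom directly on the aromatic nitrogen. Going by the values given here, no measured pair shows such a change, and the direction is open. The expected value for compound 3 is 1000 nM, within 200 nM to 6000 nM. This estimate corresponds to an expected step of a 1.6-fold higher number from compound 2 to compound 3 (0.21 log units; within the scatter), with wide uncertainty.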

Compound 3, half-maximal inhibitory concentration: 340 nM
For compound 3 the middle estimate is 2.9-fold (0.47 log units) above the measured one, within the range that was stated.
By their numbers in this assay, from the lowest: compounds 1, 3 and 2 (each within the scatter of the next, the first and the last beyond it).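

In this assay, furan-2-yl in place of 4-methoxybenzyl on the aromatic nitrogen gives a 1.8-fold lower number from compound 2 to compound 3 (0.26 log units; within the scatter), and furan-2-yl in place of 3-methoxybenzyl gives a 1.3-fold higher number from compound 1 to compound 3 (0.12 log units; within the scatter). This position therefore tolerates a group of 5 heavy atoms, a five-membered aromatic ring attached directly to the nitrogen, as well as the larger methoxybenzyl groups, and compound 3 stays within the scatter of both methoxybenzyl compounds even though those two lie beyond the scatter of each other. No measurement offered here explains this result.

Going by these compounds, it remains open how a plain phenyl ring, a thiophene ring or a small methyl group would read on this nitrogen. On these data alone, all three compounds also carry the same ethyl ester, so the effect of a carboxylic acid or an amide in its place is unknown.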